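The source may hold more compounds than are shown below. What is called first, only, known or untested is meant among the compounds shown, and "the series" means these compounds.

Compound 2 `CC(O)(CSc1ccc(Cl)cc1)c1nc(-c2ccc(F)c(Cl)c2)no1` was tested in a functional assay on DU-145 cells (Homo sapiens) for cytotoxicity, read by MTT assay (a higher number here means a weaker inhibitor, a lower number a stronger inhibitor), and gives 500 nM. Compound 2 holds the only numerical result in this assay; the one other result shown is a limit. Compound 1 `CC(O)(CSc1ccc(F)cc1)c1nc(-c2ccccc2)no1` sits at the limit of > 100000 nM in this assay, at which 1 of the 2 values shown sits. In this assay compound 1 gives > 100000 nM, which is a limit of the assay and not a number. Compound 1 and compound 2 differ from each other in more than one place, so their two results cannot be tied to any single change.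

Compound 3 `CC(O)(CSc1ccc(F)cc1)c1nc(-c2ccc(F)c(Cl)c2)no1` has not yet been measured in this assay. It differs from compound 2 in one place: fluoro in place of chloro on an aromatic carbon. Within the data shown here, no measured pair shows what this exchange does in this assay. Swapping one halogen for another at the same place is a small alteration, and the step from compound 2 to compound 3 is estimated as a 2.0-fold higher number from compound 2 to compound 3 (0.30 log units; within the scatter), a modest weakening, though a result that stays within the scatter would not surprise. On this basis compound 3 is expected to give 1000 nM in this assay, with a range from 300 nM to 5000 nM.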

Compound 3, half-maximal inhibitory concentration: 2900 nM
Compound 3: middle estimate off by 2.9-fold (0.46 log units), on the low side, and the stated range covers the measured number.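

Swapping (4-chlorophenyl)sulfanyl for (4-fluorophenyl)sulfanyl in this assay gives a 5.8-fold higher number from compound 2 to compound 3 (0.76 log units; beyond the scatter), so exchanging this single halogen, one heavy atom for another, is enough to produce a change that can be read in this assay. Compound 3 also links the two earlier compounds, which could not be compared directly, and isolates a change on the other aromatic ring: 3-chloro-4-fluorophenyl in place of phenyl gives an at least 34-fold lower number from compound 1 to compound 3 (1.53 log units; beyond the scatter), a large step next to the modest halogen swap. The result for compound 1 is a limit of the assay and not a number, so the true size of this step remains unknown: the limit of > 100000 nM in this assay, at which 1 of the 3 values shown sits.

The compounds shown leave open what a methoxy group or an amine would do in place of the halogen on the sulfanyl-linked ring, and which of the two halogens on the 3-chloro-4-fluorophenyl ring accounts for the large step. From the compounds shown here alone, they also give no explanation for either step, and whether the same steps would appear on other cell lines remains untested here.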